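The source may hold more compounds than are shown below. What is called first, only, known or untested is meant among the compounds shown, and "the series" means these compounds.

In a toxicity assay on MDCK cells (Canis lupus familiaris) for cytotoxicity, read by CCK-8 assay, with a stated time of 48 h (on this read-out higher numbers stand for lower toxicity in this test and lower numbers for higher toxicity in this test), three compounds sharing one core have been read so far. Compound 1 `O=C(NNc1c(Br)cccc1Br)c1ccc(OCC(F)(F)F)cc1` gives > 100000 nM, which is a limit of the assay. Compound 2 `N#Cc1ccc(C(=O)NNc2c(Br)cccc2Br)cc1` gives > 100000 nM, which is also a limit. Going by the values given here, compound 3 `COC(=O)c1ccc(C(=O)NNc2c(Br)cccc2Br)cc1` gives 87600 nM, the only actual number among the three.

The next structure is compound 4 `O=C(NNc1c(Br)cccc1Br)c1ccc(-c2ccccc2)cc1`, and its difference is this: phenyl in place of methoxycarbonyl on an aromatic carbon. Among the compounds with values here, two measured steps bear on the change, as each exchanges a group on an aromatic carbon: an at least 1.1-fold lower number from compound 1 to compound 3 (0.05 log units; that floor lies within the scatter), and an at least 1.1-fold lower number from compound 2 to compound 3 (0.05 log units; that floor lies within the scatter). The third, a step that the two limits leave unreadable from compound 1 to compound 2, adds nothing on size. From the compounds shown here alone, with only these two small floors from compound 1 and compound 2 to go on, no step beyond the scatter is expected in this assay, although the larger phenyl group is untested and the assay may report only a limit. The expected step is a 1.0-fold higher number from compound 3 to compound 4 (0.01 log units; within the scatter). Compound 4 is estimated at 90000 nM, with an expected range from 35000 nM to 200000 nM.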

Compound 4, half-maximal cytotoxic concentration: 84100 nM
Compound 4: the middle estimate sits 1.1-fold (0.03 log units) above what was measured; low and high end bracket the measured number.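

In this assay, phenyl in place of methoxycarbonyl brings the first aromatic ring to this position, and the result is a 1.0-fold lower number from compound 3 to compound 4 (0.02 log units; within the scatter), so this exchange, which adds heavy atoms and removes the hydrogen-bond acceptors of the ester, gives no step beyond the scatter. Measured against the two compounds held at a limit, the results are an at least 1.1-fold lower number from compound 2 to compound 4 (0.07 log units; that floor lies within the scatter) and an at least 1.1-fold lower number from compound 1 to compound 4 (0.07 log units; that floor lies within the scatter), and both of these floors also lie within the scatter. The true size of these two steps stays unknown because the values of compound 1 and compound 2 are limits, not numbers: the limit of > 100000 nM in this assay, at which 2 of the 4 values shown sit.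

From the compounds shown here alone, whether an amine or a carboxylic acid on this aromatic carbon would give a step beyond the scatter remains open. The compounds shown also say nothing about changes to the shared core.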